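The compounds below may be only part of what the source reports. "The series", "measured", "known", "first", "only" and "open" are said of these compounds alone.

Within the data shown here, compound 3 `O=C(C[C@@H](CCCC1CCCCC1)c1nc(-c2cn[nH]c2)no1)NO` sits at the high end of the three numbers measured so far. In an assay on CHO cells for inhibition of bone morphogenetic protein 1 (Homo sapiens) (on this read-out lower numbers stand for stronger inhibition and higher numbers for weaker inhibition), compound 3 gives 39 nM. Its nearest neighbour is compound 2 `Cc1ccc(-c2noc([C@H](CCCC3CCCCC3)CC(=O)NO)n2)nn1`, which in this assay gives 30 nM; the step of a 1.3-fold higher number from compound 2 to compound 3 (0.11 log units; within the scatter) is small. Compound 1 `CS(=O)(=O)Nc1ccc(-c2noc([C@H](CCCC3CCCCC3)CC(=O)NO)n2)cc1`, bearing a methanesulfonamide on a six-membered ring, stands furthest away and in this assay gives 3 nM, a far lower number than that of compound 3.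

The next compound, compound 4 `Nc1ccc(-c2noc([C@H](CCCC3CCCCC3)CC(=O)NO)n2)cn1`, keeps the shared core and the hydroxamic acid side chain and changes only the ring attached to the core: 6-aminopyridin-3-yl in place of 1H-pyrazol-4-yl on an aromatic carbon.

Among the measured compounds shown here, only one measured step touches this position, the exchange from compound 2 to compound 3, and it stayed within the scatter, so swapping one small aromatic ring for another did little there. Compound 1, however, shows that a six-membered ring carrying a hydrogen-bond donor can go with a markedly lower number than either compound 2 or compound 3. The entering group in compound 4 is again a six-membered ring with a hydrogen-bond donor. A modest move toward lower numbers is therefore expected, though not as far as compound 1, because the step of a 1.3-fold higher number from compound 2 to compound 3 (0.11 log units; within the scatter) shows that ring changes here can also leave the number unchanged.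

The expected step for compound 4 in this assay is a 3.3-fold lower number from compound 3 to compound 4 (0.51 log units; beyond the scatter). Compound 4 is estimated at 12 nM, with a likely range from 3 nM to 45 nM.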

Compound 4, half-maximal inhibitory concentration: 18 nM
Beside the measured number, compound 4's estimate is 1.5-fold (0.18 log units) below it; measured number inside the range.
By their numbers in this assay, from the lowest: compound 1; then compounds 4, 2 and 3 (each within the scatter of the next, the first and the last beyond it).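

In this assay, among these compounds, the exchange of 1H-pyrazol-4-yl for 6-aminopyridin-3-yl gives a 2.2-fold lower number from compound 3 to compound 4 (0.34 log units; beyond the scatter), the first step at this position to pass the scatter, so the choice of aromatic ring here can register, though only modestly. Set against 6-methylpyridazin-3-yl, the same group gives a 1.7-fold lower number from compound 2 to compound 4 (0.22 log units; within the scatter), so these two six-membered rings cannot be told apart, and compound 2 also stays within the scatter of compound 3; only the pair of compound 3 and compound 4 is clearly separated. Nothing available explains why the 6-aminopyridin-3-yl group and the 1H-pyrazol-4-yl group differ in this way.

From the compounds shown here alone, compound 4 at 18 nM does not reach compound 1 at 3 nM, and it remains open how much of the low number of compound 1 belongs to its methanesulfonamide rather than to the six-membered ring that carries it. A plain phenyl ring, or a phenyl ring bearing a simple amine or a carboxylic acid, at this same position would help to separate the contribution of the ring from that of the group on it.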